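The compounds below may be only part of what the source reports. "The series", "measured", "known", "first", "only" and "open" are said of these compounds alone.

Measured in a functional assay on HeLa cells (Homo sapiens) for antiproliferative activity, read by MTT assay, with a stated time of 24 h; on this read-out lower numbers stand for stronger inhibition and higher numbers for weaker inhibition:
- Compound 1 `Cc1ccc(-c2nn(-c3ccccc3)cc2-c2nc3ccccc3[nH]2)cc1`: 4950 nM
- Compound 2 `Cc1ccc(-c2nn(-c3ccccc3)cc2-c2nc3ccccc3n2S(=O)(=O)c2ccccc2)cc1`: 820 nM
- Compound 3 `Cc1ccc(-c2nn(-c3ccccc3)cc2-c2nc3ccccc3n2S(=O)(=O)c2ccc(F)cc2)cc1`: 3670 nM

Compound 3 sits close to the unsubstituted parent: a 1.3-fold lower number from compound 1 to compound 3 (0.13 log units; within the scatter). Compound 2 stands clearly apart, since a 6.0-fold lower number from compound 1 to compound 2 (0.78 log units; beyond the scatter).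

The next compound is compound 4 `Cc1ccc(-c2nn(-c3ccccc3)cc2-c2nc3ccccc3n2S(=O)(=O)c2ccc(Cl)cc2)cc1`. It differs from compound 3 by a single swap: chloro in place of fluoro on an aromatic carbon. This puts chloro in place of fluoro on an aromatic carbon, para to a large group.

Going by the values given here, no measured step makes this exact swap. The closest evidence comes from the same position, where a 4.5-fold higher number from compound 2 to compound 3 (0.65 log units; beyond the scatter). That shows a single atom there can matter, but two data points give no trend for a larger halogen. A modest shift in either direction remains possible.

The expected change is small, with a slight lean towards compound 2: a 1.7-fold lower number from compound 3 to compound 4 (0.22 log units; within the scatter). For compound 4 the estimated value is 2200 nM, with an expected range of 800 nM to 5500 nM.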

Compound 4, half-maximal inhibitory concentration: 4060 nM
For compound 4 the middle estimate is 1.8-fold (0.27 log units) below the measured one; the range from low to high includes it.
By their numbers in this assay, from the lowest: compound 2; then compounds 3, 4 and 1 (each within the scatter of the next).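

In this assay, chloro and fluoro at this place on the ring cannot be told apart (a 1.1-fold higher number from compound 3 to compound 4 (0.04 log units; within the scatter)), so the larger halogen gives the same result as the smaller one. The gap to the compound with hydrogen at this place stays beyond the scatter (a 5.0-fold higher number from compound 2 to compound 4 (0.69 log units; beyond the scatter)), while compound 4 cannot be told apart from the compound with no sulfonyl group at all (a 1.2-fold lower number from compound 1 to compound 4 (0.09 log units; within the scatter)); the lower number of compound 2 is thus lost with either halogen. No measurement available here explains why a halogen at this place has this outcome.

On these data alone, whether the loss belongs to halogens alone or to any group at this place remains open. A methoxy group, an amine or a carboxylic acid on the same carbon could keep the number of compound 2 or lose it as well.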